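This account rests on a few compounds, and the source may have more. Where it says the series, first, only, none or still open, it means among the compounds named here.

Measured so far:
compound 1 `COC(=O)C1=C(C)N=C(C)/C(=C(\O)OC)C1c1ccc(Cl)cc1`, 8130 nM in a functional assay (muscle tissue) with Cavia porcellus as the target; on this read-out higher numbers stand for an effect only at larger amounts of compound and lower numbers for an effect already at smaller amounts
compound 2 `COC(=O)C1=C(C)N=C(C)/C(=C(\O)OC)C1c1ccccc1I`, 46.8 nM in this assay
compound 3 `COC(=O)C1=C(C)N=C(C)/C(=C(\O)OC)C1c1ccc(I)cc1`, 22900 nM in this assay

Compound 1 stands second highest of the three numbers; its nearest neighbour is compound 3, a 2.8-fold higher number from compound 1 to compound 3 (0.45 log units; beyond the scatter), and its furthest is compound 2, a 170-fold lower number from compound 1 to compound 2 (2.24 log units; beyond the scatter). The step now followed leads from compound 1 to compound 4 `COC(=O)C1=C(C)N=C(C)/C(=C(\O)OC)C1c1ccccc1C`, in which (2-methylphenyl in place of 4-chlorophenyl on a saturated ring carbon). Going by the values given here, two measured steps bear on it. Moving the substituent from the 4-position to the 2-position of the phenyl ring, with iodo in place of chloro, gave a 170-fold lower number from compound 1 to compound 2 (2.24 log units; beyond the scatter), and the reverse move from 2-iodophenyl to 4-iodophenyl gave a 490-fold higher number from compound 2 to compound 3 (2.69 log units; beyond the scatter). Both point the same way: a substituent at the 2-position of the phenyl ring goes with a much lower number than one at the 4-position. Among the compounds with values here, compound 4 also carries its substituent at the 2-position, though methyl rather than iodo, and no measured compound shows what methyl alone does. Within the data shown here, a large step downward is therefore expected, a 54-fold lower number from compound 1 to compound 4 (1.73 log units; beyond the scatter), perhaps somewhat smaller than the one to compound 2. Compound 4 is estimated at 150 nM, within 30 nM to 800 nM.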

Compound 4, half-maximal effective concentration: 6.03 nM
Estimate against measurement, compound 4: 25-fold (1.40 log units) above, outside the stated range (below it).
By their numbers in this assay, from the lowest: compound 4; then compound 2; then compound 1; then compound 3.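

With 2-methylphenyl on the saturated ring carbon, the number in this assay falls further than with 2-iodophenyl, a 7.8-fold lower number from compound 2 to compound 4 (0.89 log units; beyond the scatter), so the low numbers at this place do not depend on iodo. The distance from the 4-substituted compounds also grows, with a 1300-fold lower number from compound 1 to compound 4 (3.13 log units; beyond the scatter) and a 3800-fold lower number from compound 3 to compound 4 (3.58 log units; beyond the scatter), and in these four compounds both 2-substituted phenyl groups stand far below both 4-substituted ones. Nothing at hand accounts for these differences.

The compounds shown leave open whether methoxy, an amine or a carboxylic acid at the 2-position would also give such low numbers, and whether a longer chain such as ethyl would go further or lose ground. They also leave open where 4-methylphenyl would stand, which would show what moving the methyl group alone does.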